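From compound 3 to its 4-hydroxyphenyl counterpart

The source may report more compounds than this note shows. Statements on the series, on what has been measured and on what is new or still open speak of the compounds shown alone.

Compound 3 `CN1CCN(c2nc(-c3cccc(O)c3)nc3[nH]cnc23)CC1` was examined in an assay on cells for displacement of a labelled ligand from adenosine receptor A1 (Homo sapiens), read by scintillation counting and radioligand binding, with a stated time of 60 min, tested at 10 uM; a higher number here means more inhibition at the concentration tested (going by the name of the read-out), a lower number less inhibition. In this assay compound 3 gives > 80%, which is a limit of the assay and not a number. Its two neighbours that differ from it in one place sit at the same ceiling. Compound 1 `CN1CCN(c2nc(-c3cccc(Cl)c3)nc3[nH]cnc23)CC1` gives > 80% in this assay, again a limit rather than a number. Compound 2 `Oc1cccc(-c2nc(N3CCCCC3)c3nc[nH]c3n2)c1` gives > 80% in this assay, also a limit. As a result the step that the two limits leave unreadable from compound 1 to compound 3 and the step that the two limits leave unreadable from compound 2 to compound 3 carry no readable size, since (the limit of > 80% in this assay, at which 3 of the 3 values shown sit).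

Compound 4 `CN1CCN(c2nc(-c3ccc(O)cc3)nc3[nH]cnc23)CC1` has not yet been measured. It differs from compound 3 by 4-hydroxyphenyl in place of 3-hydroxyphenyl on an aromatic carbon. Among the measured compounds shown here, no measured step touches this particular change, and the two neighbouring steps tell nothing about size. What the three values do show is that every measured member of this shared core reached the limit, so a step that the limit leaves unreadable from compound 3 to compound 4 is expected, that is, nothing beyond the scatter. Compound 4 is therefore estimated at 88% in this assay, within a range from 70% to 100%, and it is expected most likely to be reported once more only as a limit.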

Compound 4, a percentage reported as inhibition, at one concentration (the size of the read-out at that concentration, not a potency): > 80%
Compound 4 was reported as a limit; the forecaster's own chance of this, stated with the estimate: 80%; the middle value is on the limit's open side.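

Compound 4 is reported only as a limit, as are compound 1 and compound 3, so neither its step from compound 3 nor its step from compound 1 can be read, because all the values share one ceiling: the limit of > 80% in this assay, at which 4 of the 4 values shown sit.

The compounds shown leave open whether 4-hydroxyphenyl in place of 3-hydroxyphenyl makes any difference in this assay.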